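Ester variation and tolerated concentration: step to compound 3

This account rests on a few compounds, and the source may have more. Where it says the series, first, only, none or still open, it means among the compounds named here.

Measured so far in a functional assay on HeLa cells (Homo sapiens) for cytotoxicity; a lower number here means that less compound is tolerated, a higher number that more compound is tolerated:
compound 1 `COCCOC(=O)C(O)Cn1cnc2c(N)ncnc21`: > 400 ug/mL (a limit of the assay)
compound 2 `CCCCOC(=O)C(O)Cn1cnc2c(N)ncnc21`: 400 ug/mL

Compound 2 holds the only number shown in this assay, 400 ug/mL. Among the compounds with values here, the one other value is a limit. Compound 1 gives in this assay only the limit > 400 ug/mL. Within the data shown here, the single measured step, a number no higher from compound 1 to compound 2 (the limit leaves the size open), cannot be sized because of the limit of > 400 ug/mL in this assay, at which 1 of the 2 values shown sits, and it alters the length and heteroatom content of the ester chain rather than its branching. Compound 3 `CCC(C)OC(=O)C(O)Cn1cnc2c(N)ncnc21` differs from compound 2 by sec-butyl in place of butyl on an oxygen next to a carbonyl group. Among the measured compounds shown here, no measured step of this kind exists, so the expectation rests on compound 2 alone and on the unchanged atom count. The step in this assay is expected to be no change at the digits printed from compound 2 to compound 3 (within the scatter), none beyond the scatter. Compound 3 is estimated at 400 ug/mL, within 200 ug/mL to 800 ug/mL, with a real chance that only a limit is reported.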

Compound 3, minimum cytotoxic concentration: > 400 ug/mL
Compound 3 ended at the assay's limit (the forecaster's own chance of this, stated with the estimate: 50%); the middle value sits exactly at the limit.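

In this assay compound 3 gives > 400 ug/mL, which is a limit of the assay and not a number. Within the data shown here, exchanging butyl for sec-butyl on an oxygen next to a carbonyl group gives a number no lower from compound 2 to compound 3 (the limit leaves the size open), so this position accepts a branched chain with no sign of less compound being tolerated, something the two unbranched esters could not show. Neither the size of that step nor the step between the two limit compounds can be read: the limit of > 400 ug/mL in this assay, at which 2 of the 3 values shown sit.

On these data alone, how far the tolerated concentrations of compound 1 and compound 3 extend past the limit stays open, and with it any ranking of the three esters. Also open, as far as these compounds go, is whether an ester chain carrying an amine or a carboxylic acid, or a longer chain, would give a lower number in this assay.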